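Swapping methyl for methoxy: compound 1 to compound 4

A few compounds are considered here, and "the series" means these few. Any claim that something is new, unique, unknown or untested is made for them only; others in the source may bear on it.

Measured in a functional assay on HCT-116 cells (Homo sapiens) for antiproliferative activity, read by MTT assay, with a stated time of 72 h; a higher number here means a weaker inhibitor, a lower number a stronger inhibitor:
- compound 1 `COc1ncc(-c2ccc3c(c2)N(c2ccc(C)cc2)C(=O)CO3)cc1NS(=O)(=O)c1ccc(F)cc1` gives 22700 nM
- compound 2 `O=C1COc2ccc(-c3cccc(NS(=O)(=O)c4ccc(F)cc4)c3)cc2N1` gives > 40000 nM (a limit of the assay, not a number)
- compound 3 `CC(C)N1C(=O)COc2ccc(-c3cccc(NS(=O)(=O)c4ccc(F)cc4)c3)cc21` gives 22600 nM

Only two of these three results are true numbers. In this assay compound 1 gives 22700 nM and compound 3 gives 22600 nM, and these two numbers lie within the usual scatter of each other. Compound 1 therefore has the higher of the two numbers only on paper, and no real gap separates them.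

The next compound to be tested is compound 4 `COc1ccc(N2C(=O)COc3ccc(-c4cnc(OC)c(NS(=O)(=O)c5ccc(F)cc5)c4)cc32)cc1`. It differs from compound 1 in one place: methoxy in place of methyl on an aromatic carbon. In words, methoxy stands in place of methyl on an aromatic carbon, para to a large group, turning 4-methylphenyl into 4-methoxyphenyl.

For the measured compounds named here, no measured pair makes this swap. Going by the values given here, the only measured step, an at least 1.7-fold lower number from compound 2 to compound 3 (0.24 log units; that floor lies within the scatter), concerns a different change, isopropyl in place of hydrogen on an amide-type nitrogen in a ring, so it says little about this one. With compound 1 at 22700 nM as the best guide, no shift beyond the scatter is expected in this assay. The expected change is small: a 1.1-fold lower number from compound 1 to compound 4 (0.05 log units; within the scatter). For compound 4 the estimated value is 20000 nM, with an expected range from 9000 nM to 40000 nM.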

Compound 4, half-maximal inhibitory concentration: 13400 nM
Compound 4: middle estimate off by 1.5-fold (0.17 log units), on the high side; the measured number falls inside the stated range.
By their numbers in this assay, from the lowest: compounds 4, 3 and 1 (each within the scatter of the next). At a limit, above all of these: compound 2.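

For the compounds shown here, this pair gives the first reading of a change on the outer phenyl ring of compound 1, as the earlier step concerned only the group on the ring nitrogen: in this assay, the swap gives a 1.7-fold lower number from compound 1 to compound 4 (0.23 log units; within the scatter). Both compounds have true numbers rather than limits, so the size of the step can be read directly, and it shows that turning 4-methylphenyl into 4-methoxyphenyl, which brings in an oxygen counted as a hydrogen-bond acceptor, does not move the result beyond the usual scatter of repeated measurements. Nothing measured here explains the small difference, and this single pair cannot separate it from that scatter.

On these data alone, it remains open whether this place on the ring responds to anything more different from methyl and methoxy, such as an amine, a carboxylic acid or a longer chain like butoxy, any of which might shift the number beyond the scatter. Going by these compounds alone, it is also open whether the swap from methyl to methoxy would give a similarly small step on a different group at the ring nitrogen, since only this one pair carries it.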